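A few compounds are considered here, and "the series" means these few. Any claim that something is new, unique, unknown or untested is made for them only; others in the source may bear on it.

Measured compounds in a functional assay on NCI-H23 cells (Homo sapiens) for cytotoxicity, read by sulforhodamine B assay, with a stated time of 48 h, tested at 10 uM; on this read-out higher numbers stand for a weaker effect at the one concentration tested and lower numbers for a stronger effect:
- compound 1, `COc1ccc(-c2cc(/C=C/C(=O)c3ccc(OC)c(OC)c3)[nH]n2)cc1`, gives -24%
- compound 2, `COc1cc(-c2cc(/C=C/C(=O)c3ccc(Cl)c(Cl)c3)[nH]n2)cc(OC)c1OC`, gives 79%
- compound 3, `COc1ccc(-c2cc(/C=C/C(=O)c3ccc(N)cc3)[nH]n2)cc1`, gives 8%

Among these three, compound 2 stands at the highest number, which on this read-out means the weakest effect; its gap to compound 3 and its wider gap to compound 1 both lie beyond the usual scatter of repeated measurements. Compound 2 is now the starting point for a single change that gives compound 4, `COc1cc(-c2cc(/C=C/C(=O)c3ccc(F)c(F)c3)[nH]n2)cc(OC)c1OC`, which has not yet been measured in this assay.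

The change is 3,4-difluorophenyl in place of 3,4-dichlorophenyl on a carbonyl carbon. For the measured compounds named here, the three measured compounds differ from each other in more than one place at once, so no step with a single change is available, and nothing among them shows how a swap of one halogen for another on the same phenyl ring affects this read-out. The expectation for compound 4 is therefore a step that is small, a number 9 percentage points lower from compound 2 to compound 4 (within the scatter), without a confident direction, and possibly not beyond the scatter. On that basis compound 4 is estimated at 70%, within a range from 40% to 100%.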

Compound 4, a percentage reported as activity, at one concentration (the size of the read-out at that concentration, not a potency): -7%
The estimate for compound 4 lay 77 percentage points above the measured number; measured number outside the range, below it.
By their numbers in this assay, from the lowest: compound 1; then compound 4; then compound 3; then compound 2.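

In this assay the choice of halogen on this phenyl ring matters a great deal, with a number 86 percentage points lower from compound 2 to compound 4 (beyond the scatter) and so a much stronger effect. At this place, on a carbonyl carbon, 3,4-difluorophenyl in place of 3,4-dichlorophenyl keeps the count of heavy atoms and the ring the same, yet this exchange of chlorine for fluorine alone is enough to turn a weak compound into a strong one. Nothing available explains why the two halogens differ so sharply.

Going by these compounds, it remains open whether 3,4-dibromophenyl or an unsubstituted phenyl at the same place would fall nearer to compound 2 or to compound 4. Also open, on these data alone, is whether 3,4-difluorophenyl and 3,4-dichlorophenyl would stand this far apart on the core of compound 1.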